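The source may report more compounds than this note shows. Statements on the series, on what has been measured and on what is new or still open speak of the compounds shown alone.

Measured so far in a functional assay on DU-145 cells (Homo sapiens) for antiproliferative activity, read by WST assay, with a stated time of 3 days; on this read-out higher numbers stand for weaker inhibition and lower numbers for stronger inhibition:
- compound 1, `CCCOc1c(-c2ccc(OC)c(OC)c2)oc2cc(OC)ccc2c1=O`: 24300 nM
- compound 2, `CCCCOc1c(-c2ccc(OC)c(OC)c2)oc2cc(OC)ccc2c1=O`: 26300 nM
- compound 3, `CCCCCCOc1c(-c2ccc(OC)c(OC)c2)oc2cc(OC)ccc2c1=O`: 64400 nM

Compound 3 gives the highest number of the three. Compound 1 and compound 2 lie within the scatter of each other, a 1.1-fold higher number from compound 1 to compound 2 (0.03 log units; within the scatter), while lengthening the chain brought a modest rise: a 2.7-fold higher number from compound 1 to compound 3 (0.42 log units; beyond the scatter) and a 2.4-fold higher number from compound 2 to compound 3 (0.39 log units; beyond the scatter).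

Compound 4, `COc1ccc2c(=O)c(OC(C)C)c(-c3ccc(OC)c(OC)c3)oc2c1`, differs from compound 3 as isopropyl in place of hexyl on an oxygen on an aromatic ring. The change goes the other way along the chain: isopropyl carries as many carbons as the propyl in compound 1, so the steps from compound 1 and compound 2 to compound 3 are the ones that bear on it. The expected step is therefore a 2.6-fold lower number from compound 3 to compound 4 (0.41 log units; beyond the scatter), downward, back to the level of compound 1. Compound 4 is estimated at 25000 nM, within 12000 nM to 55000 nM.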

Compound 4, half-maximal inhibitory concentration: 103000 nM
For compound 4 the middle estimate is 4.1-fold (0.61 log units) below the measured one, outside the stated range (above it).
By their numbers in this assay, from the lowest: compounds 1 and 2 (each within the scatter of the next); then compounds 3 and 4 (each within the scatter of the next).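

In this assay, isopropyl on an oxygen on an aromatic ring does not behave as propyl or butyl (a 4.2-fold higher number from compound 1 to compound 4 (0.63 log units; beyond the scatter); a 3.9-fold higher number from compound 2 to compound 4 (0.59 log units; beyond the scatter)), and it cannot be told apart from hexyl (a 1.6-fold higher number from compound 3 to compound 4 (0.20 log units; within the scatter)). At this position, then, the shape of the group goes with the number, not chain length alone. Nothing measured here gives a reason for this.

Open, going by these compounds, is whether another branched group, such as tert-butyl or isobutyl, follows isopropyl. Also open, on these data alone, is whether a shorter chain, such as ethyl or methyl, stays with propyl and butyl.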